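From Ethyl to Pyrimidin-2-yl on a Ring Amine Nitrogen

A few compounds are considered here, and "the series" means these few. Any claim that something is new, unique, unknown or untested is made for them only; others in the source may bear on it.

In an in vitro ADME assay on microsomes from liver (Mus musculus) for pharmacokinetics, read by LC-MS, with a stated time of 10 min, tested at 1 uM (a lower number here means slower removal, a higher number faster removal of the compound), compound 1 `CN1C[C@H](C(=O)Nc2ccc(F)cc2)[C@@H](c2ccc(/C=C/C(=O)Nc3ccccc3N)cc2)C1` gives 34 mL/min/kg, compound 2 `CN1C[C@H](C(=O)Nc2ccc(C3CC3)cc2)[C@@H](c2ccc(/C=C/C(=O)Nc3ccccc3N)cc2)C1` gives 60 mL/min/kg and compound 3 `CCN1C[C@H](C(=O)Nc2ccc(Cl)cc2)[C@@H](c2ccc(/C=C/C(=O)Nc3ccccc3N)cc2)C1` gives 35 mL/min/kg. Compound 3 therefore stands within the scatter of both other compounds, and the three values cannot be ranked with confidence.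

Compound 4 `Nc1ccccc1NC(=O)/C=C/c1ccc([C@H]2CN(c3ncccn3)C[C@@H]2C(=O)Nc2ccc(Cl)cc2)cc1` carries pyrimidin-2-yl in place of ethyl on an amine nitrogen in a ring, and its difference from compound 3 is pyrimidin-2-yl in place of ethyl on an amine nitrogen in a ring. Going by the values given here, only one measured step that differs in a single place is available, and it does not touch that nitrogen. This step, a 1.8-fold higher number from compound 1 to compound 2 (0.25 log units; within the scatter), places cyclopropyl in place of fluoro on an aromatic carbon and stays within the scatter. It bears on the new change only indirectly, by showing that one substitution in this series left the number inside the usual spread. The data contain no direct measure of a pyrimidin-2-yl group on the amine nitrogen, so the expectation remains loose. The expected change is small and slightly upward, with the estimated step being a 1.3-fold higher number from compound 3 to compound 4 (0.11 log units; within the scatter), which is no clear move beyond the scatter. For compound 4 the expected value is 45 mL/min/kg, with an estimated range from 22 mL/min/kg to 90 mL/min/kg.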

Compound 4, clearance: 44 mL/min/kg
Compound 4: middle estimate off by 1.0-fold (0.01 log units), on the high side; measured number inside the range.
By their numbers in this assay, from the lowest: compounds 1, 3, 4 and 2 (each within the scatter of the next).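

Going by these compounds alone, this is the first measured step at the amine nitrogen in a ring, and in this assay the exchange of ethyl for pyrimidin-2-yl gives a 1.3-fold higher number from compound 3 to compound 4 (0.10 log units; within the scatter). The earlier compounds carried only small open groups at this nitrogen, and their one listed step concerned the aromatic carbon of the anilide. The result therefore shows that this position can take a group of 6 heavy atoms in place of one of 2, with a six-membered aromatic ring and 2 hydrogen-bond acceptors entering where there had been no ring and no acceptor, without the clearance number leaving the scatter. No measurement shown here accounts for this outcome or separates the contributions of the ring and its nitrogens. The compounds shown leave open whether a phenyl ring, a pyridin-2-yl group, an acetyl group or an unsubstituted amine at this nitrogen would stay as close to compound 3, and whether pyrimidin-2-yl would behave alike with fluoro or cyclopropyl in place of the chloro group of compound 4.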